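The source may hold more compounds than are shown below. What is called first, only, known or untested is meant among the compounds shown, and "the series" means these compounds.

For the measured compounds named here, compound 3, `COc1cccc(N2CCN(CCCC(=O)Nc3ccc(Cl)cc3)CC2)c1`, stands second highest of the three numbers so far in an assay on HEK293 cells for inhibition of Voltage-dependent T-type calcium channel subunit alpha-1G (Homo sapiens), read by patch clamp, tested at 10 uM; a lower number here means less inhibition, a higher number more inhibition at the concentration tested (going by the name of the read-out). Compound 1, `O=C(CCCN1CCN(c2ccccc2)CC1)Nc1ccc(Cl)cc1`, gives 75.1%, and compound 2, `O=C(CCCN1CCN(c2ccc(Cl)cc2)CC1)Nc1ccc(Cl)cc1`, gives 94.6%; compound 3 gives 84.1%. The nearest neighbour of compound 3 is compound 1, a number 9 percentage points higher from compound 1 to compound 3 (within the scatter), while a number 10.5 percentage points lower from compound 2 to compound 3 (beyond the scatter) puts compound 2 beyond the scatter above it.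

Compound 4, `COc1cccc(N2CCN(CCCC(=O)Nc3ccc(Cl)cc3Cl)CC2)c1`, differs from compound 3 by chloro in place of hydrogen on an aromatic carbon. Among the measured steps, a number 19.5 percentage points higher from compound 1 to compound 2 (beyond the scatter) is the same kind of change in name, chloro in place of hydrogen on an aromatic carbon, though on a different part of the molecule; a number 9 percentage points higher from compound 1 to compound 3 (within the scatter) shows that a single aromatic substituent added elsewhere can also stay within the scatter. Going by the values given here, no measured step places a chloro ortho to a large group and meta to a chloro group, so the closest guide remains the modest gain from compound 1 to compound 2. Since compound 3 already sits at 84.1%, the room upward is limited. The writer therefore expects a modest rise, a number 5.9 percentage points higher from compound 3 to compound 4 (within the scatter), and estimates that compound 4 gives 90%, within 78% to 98%.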

Compound 4, a percentage reported as inhibition, at one concentration (the size of the read-out at that concentration, not a potency): 80.3%
Beside the measured number, compound 4's estimate is 9.7 percentage points above it; measured number inside the range.
By their numbers in this assay, from the lowest: compounds 1, 4 and 3 (each within the scatter of the next); then compound 2.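

In this assay, turning 4-chlorophenyl into 2,4-dichlorophenyl, with the chloro ortho to a large group and meta to a chloro group, gives a number 3.8 percentage points lower from compound 3 to compound 4 (within the scatter), so this position accepts a chloro without a change that can be told from scatter. The earlier compounds had shown this change only as a rise, on the phenyl group carried by the amine nitrogen in a ring, and the gain seen there does not carry over to this place: the same change on two cores in this assay, a number 19.5 percentage points higher (beyond the scatter) from compound 1 to compound 2 and a number 3.8 percentage points lower (within the scatter) from compound 3 to compound 4, 23.3 percentage points apart, beyond the scatter of two such steps. The two steps differ both in the ring that takes the chloro and in the rest of the molecule, so these compounds cannot say which of the two accounts for the gap.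

The compounds shown leave open whether a fluoro, methyl or methoxy group at this same position would also stay within the scatter of compound 3, or whether only the chloro behaves this way. They also leave open whether a longer chain between the amide and the amine nitrogen would change how this position responds to substitution.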